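Mirror Image of Compound 3: What Solubility to Expect

This account rests on a few compounds, and the source may have more. Where it says the series, first, only, none or still open, it means among the compounds named here.

Of the compounds shown here, three sharing one core have been measured in a physicochemical assay for solubility, at pH 7; on this read-out higher numbers stand for higher solubility and lower numbers for lower solubility. Compound 1 `O=C(Nc1ccccc1)N1CCc2[nH]nc(-c3ccccc3)c2C1` gives 153000 nM. Compound 2 `O=C(Nc1cccc(Cl)c1)N1CCc2[nH]nc(-c3ccccc3)c2C1` carries a chloro group on an aromatic carbon and gives 20000 nM; the step of a 7.7-fold lower number from compound 1 to compound 2 (0.88 log units; beyond the scatter). Compound 3 `C[C@H]1Cc2[nH]nc(-c3ccccc3)c2CN1C(=O)Nc1cccc(Cl)c1` adds a methyl group on a saturated ring carbon and gives 19000 nM; the step of a 1.1-fold lower number from compound 2 to compound 3 (0.02 log units; within the scatter). Among the three, compound 3 holds the lowest number, although its value and that of compound 2 lie within the scatter of each other, while compound 1 sits well above both.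

Compound 4 `C[C@@H]1Cc2[nH]nc(-c3ccccc3)c2CN1C(=O)Nc1cccc(Cl)c1` differs from compound 3 in one respect only: the two compounds have the same atoms and bonds and differ only in configuration as drawn: 1 of 1 stereo elements differ; a stereocentre at a saturated ring carbon is drawn S in compound 3 and R in compound 4. Compound 3 and compound 4 are thus mirror images of one another, built from the same atoms joined in the same way. Neither measured step concerns a change of configuration alone; both involved adding a group, and so neither bears directly on this change. With nothing added and nothing removed, no step beyond the scatter is expected in this assay. Compound 4 is therefore estimated at 19000 nM, within a range of 9500 nM to 38000 nM. The expected step of no change at the digits printed from compound 3 to compound 4 (within the scatter) is accordingly small.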

Compound 4, solubility: 20000 nM
Beside the measured number, compound 4's estimate is 1.1-fold (0.02 log units) below it; the measured number falls inside the stated range.
By their numbers in this assay, from the lowest: compounds 3, 2 and 4 (each within the scatter of the next); then compound 1.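

In this assay, among the compounds shown here, the earlier steps showed only what happens when a group is added, whereas this pair isolates the configuration at the saturated ring carbon, and the result is a 1.1-fold higher number from compound 3 to compound 4 (0.02 log units; within the scatter). Drawing this stereocentre R instead of S therefore leaves the two numbers within the scatter of each other, and the comparison is a clean one, with no other structural difference to take into account: the fact that compounds 3 and 4 differ only in the configuration as drawn. For the compounds shown here, the R form also matches the compound without the methyl group, the result being no change at the digits printed from compound 2 to compound 4 (within the scatter), so on this evidence neither configuration of the methyl group moves the number beyond the scatter, something the single step to the S form could not show alone.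

Going by these compounds, whether this holds only for a group as small as methyl remains open, since an ethyl group, a hydroxymethyl group or an amine on the same saturated ring carbon might separate the two mirror images or shift both away from compound 2. Also open, on these data alone, is whether the methyl group and its configuration would behave the same way on the shared core without the chloro group, as in compound 1, whose number lies well above the others.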